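The source may hold more compounds than are shown below. What is called first, only, known or untested is meant among the compounds shown, and "the series" means these compounds.

Compound 2 `CC#C[C@H]1CN(S(=O)(=O)c2ccc(N)nc2)CCN1c1ccc(C(=O)NC)cc1` gives 4050 nM in an assay on cells (Hepatocyte) for inhibition of glucokinase regulatory protein (Mus musculus), with stated times of 20 min and 40 min (a higher number here means that more compound is needed for the effect, a lower number that less compound is needed), and stands highest of the two numbers measured; compound 1 `CC#C[C@H]1CN(S(=O)(=O)c2ccc(N)nc2)CCN1c1ccc(S(N)(=O)=O)cc1` gives 37 nM. Going by the values given here, the one step on record, a 110-fold higher number from compound 1 to compound 2 (2.04 log units; beyond the scatter), is large and beyond the scatter. Compound 3 `CC#C[C@H]1CN(S(=O)(=O)c2ccc(N)nc2)CCN1c1ccc([S+](C)[O-])cc1` differs from compound 2 by a group of 3 heavy atoms (1 carbon, 1 oxygen, 1 sulfur; no ring) in place of a group of 4 heavy atoms (2 carbon, 1 nitrogen, 1 oxygen; no ring), on an aromatic carbon: a group of 3 heavy atoms (1 carbon, 1 oxygen, 1 sulfur) replaces the methylcarbamoyl. Since the sulfur-bearing group of compound 1 went with a far lower number, a lower number is expected for compound 3, though the new group is not sulfamoyl, so only part of that step, an 8.1-fold lower number from compound 2 to compound 3 (0.91 log units; beyond the scatter), is expected. Compound 3 is therefore estimated at 500 nM, between 100 nM and 2500 nM.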

Compound 3, half-maximal effective concentration: > 12500 nM
Compound 3 ended at the assay's limit; the forecaster's own chance of this, stated with the estimate: 3%; at least 25-fold (1.39 log units) between middle value and limit.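

In this assay, compound 3 stands at a limit and not at a number: the limit of > 12500 nM in this assay, at which 1 of the 3 values shown sits. The sulfur-bearing group entering here does not behave like sulfamoyl, with an at least 330-fold higher number from compound 1 to compound 3 (2.52 log units; beyond the scatter), and it also falls behind methylcarbamoyl, with an at least 3.0-fold higher number from compound 2 to compound 3 (0.48 log units; beyond the scatter). Among these compounds, then, sulfur on this aromatic carbon, para to a large group, does not by itself go with a low number; only sulfamoyl does. Going by these compounds, whether a methylsulfonyl group, a primary carboxamide, an amine or a carboxylic acid at this place would come near compound 1 stays open.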